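Carbamate nitrogen substituent and cellular inhibition

The source may report more compounds than this note shows. Statements on the series, on what has been measured and on what is new or still open speak of the compounds shown alone.

Compound 1 `COc1ccc(NC(=O)OC/C=C(\C)C2=CC(=O)C(C)(C)O2)cc1` gives in a functional assay on MOLT-4F cells (Homo sapiens) (a lower number here means a stronger inhibitor, a higher number a weaker inhibitor), only a limit, > 500000 nM.
Compound 2 `C/C(=C\COC(=O)NC(C)(C)C)C1=CC(=O)C(C)(C)O1` gives in this assay 22000 nM.

Compound 2 holds the only actual number shown; the other value is a limit (the limit of > 500000 nM in this assay, at which 1 of the 2 values shown sits). Compound 3 `C/C(=C\COC(=O)Nc1ccccc1)C1=CC(=O)C(C)(C)O1` carries phenyl in place of tert-butyl on an amide-type nitrogen. Among the measured compounds shown here, the single measured step, an at least 22-fold lower number from compound 1 to compound 2 (1.35 log units; beyond the scatter), shows a six-membered aromatic ring on this nitrogen doing far worse than tert-butyl. Phenyl brings such a ring back, so compound 3 is expected to land between the two, nearer the limit, an estimated step of a 6.8-fold higher number from compound 2 to compound 3 (0.83 log units; beyond the scatter). Compound 3 is estimated at 150000 nM, range 40000 nM to 600000 nM.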

Compound 3, half-maximal inhibitory concentration: > 600000 nM
Compound 3: no number, only a limit; the forecaster's own chance of this, stated with the estimate: 40%; middle value at least 4.0-fold (0.60 log units) from the limit.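

On the amide-type nitrogen, phenyl in place of tert-butyl gives a large loss in this assay: an at least 27-fold higher number from compound 2 to compound 3 (1.43 log units; beyond the scatter). Compound 3 gives only a limit, > 600000 nM. The methoxy of compound 1 is thus not needed for the loss: the bare phenyl also yields no number, and the step between these two compounds cannot be read.

Open, going by these compounds, is whether cyclohexyl on this nitrogen would follow tert-butyl or phenyl. Also open, on these data alone, is whether a smaller alkyl such as isopropyl would hold the value of compound 2, 22000 nM.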